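The source may report more compounds than this note shows. Statements on the series, on what has been measured and on what is new or still open speak of the compounds shown alone.

Compound 2 `COc1ccc2[nH]c(C(=O)N3CC(=O)N(Cc4ccccc4)[C@@H](COc4ccc(F)cc4)C3)cc2c1` is one of only two compounds measured in a physicochemical assay for solubility, read by spectrophotometry, in phosphate buffer, with a stated time of 2 h, at pH 7.4 (on this read-out lower numbers stand for lower solubility and higher numbers for higher solubility), and compound 2 gives the single plain number shown there, 17500 nM. Compound 1 `COc1ccc2[nH]c(C(=O)N3CC(=O)N(Cc4ccccc4)[C@@H](CCN4CCC5(CC4)CC5)C3)cc2c1` returns only a limit of the assay, > 25000 nM, as recorded in the limit of > 25000 nM in this assay, at which 1 of the 2 values shown sits. Going by the values given here, the one measured step, an at least 1.4-fold lower number from compound 1 to compound 2 (0.15 log units; that floor lies within the scatter), exchanges a group on a saturated chain carbon bound to a saturated ring carbon, and its floor lies within the scatter. Compound 3 `COc1ccc2[nH]c(C(=O)N3CC(=O)N(Cc4ccccc4)[C@@H](CN4C(=O)c5ccccc5C4=O)C3)cc2c1` differs from compound 2 at that same place: a group of 11 heavy atoms (8 carbon, 1 nitrogen, 2 oxygen; one five-membered non-aromatic ring with 1 hetero atom, one six-membered aromatic ring of carbon only) in place of a group of 8 heavy atoms (6 carbon, 1 oxygen, 1 fluorine; one six-membered aromatic ring of carbon only), on a saturated chain carbon bound to a saturated ring carbon. Among the compounds with values here, the measured step at this position gives no direction that clears the scatter, so nothing among the measured compounds points to a large change. For compound 3 a modest downward step of a 1.8-fold lower number from compound 2 to compound 3 (0.24 log units; within the scatter) in this assay is expected. Compound 3 is therefore estimated at 10000 nM, within a range of 3000 nM to 25000 nM.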

Compound 3, solubility: > 100000 nM
Compound 3: no number, only a limit (the forecaster's own chance of this, stated with the estimate: 10%); middle value at least 10-fold (1.00 log units) from the limit.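

In this assay, the place on a saturated chain carbon bound to a saturated ring carbon now gives a step beyond the scatter: an at least 5.7-fold higher number from compound 2 to compound 3 (0.75 log units; beyond the scatter). Going by these compounds alone, the earlier step at this place, an at least 1.4-fold lower number from compound 1 to compound 2 (0.15 log units; that floor lies within the scatter), showed no direction that could be read, so this is the first sign that the group here can shift the number by more than the scatter. Compound 3 gives a limit of the assay and not a number: the limit of > 100000 nM in this assay, at which 1 of the 3 values shown sits.

As far as these compounds go, the step between compound 1 and compound 3 cannot be read, and the full size of the step to compound 3 stays open. Also open, from the compounds shown here alone, is which part of the entering group goes with the higher number, and how a simple phenyl ring, a primary amine or a carboxylic acid at this place would read.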